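Hydroquinone ring exchanged for a non-aromatic dione

This account rests on a few compounds, and the source may have more. Where it says the series, first, only, none or still open, it means among the compounds named here.

Measured compounds:
- compound 1, `NS(=O)(=O)c1ccc(-n2nc(-c3ccccc3)cc2-c2cc(O)ccc2O)cc1`: 98200 nM
- compound 2, `NS(=O)(=O)c1ccc(-n2nc(-c3ccc(Cl)cc3)cc2-c2cc(O)ccc2O)cc1`: 50900 nM
- compound 3, `CC(=O)NS(=O)(=O)c1ccc(-n2nc(-c3ccc(Cl)cc3)cc2-c2cc(O)ccc2O)cc1`: 81200 nM

All three were tested in a functional assay on cells (Cancer cell lines, Homo sapiens) for cytotoxicity, read by sulforhodamine B assay, with a stated time of 48 h; on this read-out lower numbers stand for stronger inhibition of growth and higher numbers for weaker inhibition of growth. Compound 2 gives the lowest number of the three, but its separation from the others is small: a 1.9-fold lower number from compound 1 to compound 2 (0.29 log units; within the scatter), and a 1.6-fold higher number from compound 2 to compound 3 (0.20 log units; within the scatter). Neither step exceeds the scatter, so the three compounds cannot be ranked against one another.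

Compound 4, `NS(=O)(=O)c1ccc(-n2nc(-c3ccc(Cl)cc3)cc2C2=CC(=O)C=CC2=O)cc1`, has not yet been measured. It differs from compound 2 in one place: a group of 8 heavy atoms (6 carbon, 2 oxygen; one six-membered non-aromatic ring of carbon only) in place of a group of 8 heavy atoms (6 carbon, 2 oxygen; one six-membered aromatic ring of carbon only), on an aromatic carbon. Neither of the measured steps touches this part of the molecule; the chloro step and the acetyl step each changed a different position, and each stayed within the scatter. Among the compounds with values here, there is therefore no measured step that bears on the exchange of the ring, and the expectation for compound 4 rests on the value of compound 2 alone, 50900 nM, with a wide range. Compound 4 is estimated at 40000 nM, between 8000 nM and 150000 nM, which means an expected 1.3-fold lower number from compound 2 to compound 4 (0.10 log units; within the scatter).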

Compound 4, concentration for total growth inhibition: 65700 nM
The estimate for compound 4 lay 1.6-fold (0.22 log units) below the measured number; low and high end bracket the measured number.
By their numbers in this assay, from the lowest: compounds 2, 4, 3 and 1 (each within the scatter of the next).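

In this assay, the non-aromatic dione ring in place of the 2,5-dihydroxyphenyl group gives a 1.3-fold higher number from compound 2 to compound 4 (0.11 log units; within the scatter), so the two compounds cannot be told apart. This is the first change shown at this position, and it swaps an aromatic ring with 2 hydrogen-bond donors for a non-aromatic ring with 0, yet the read-out does not separate them. Nothing available explains this result.

All four compounds remain within the scatter of their neighbours in the ranking, so no change shown so far clearly moves growth inhibition in either direction. From the compounds shown here alone, it remains open whether a plain phenyl ring, an amine or a carboxylic acid at this position would give a number clearly different from that of compound 2.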